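This account rests on a few compounds, and the source may have more. Where it says the series, first, only, none or still open, it means among the compounds named here.

In a functional assay on MCF7 cells (Homo sapiens) for cytotoxicity, read by WST assay, with a stated time of 72 h (on this read-out lower numbers stand for stronger inhibition and higher numbers for weaker inhibition), the measured compounds are:
compound 1 `O=C1Nc2c(ccc(F)c2F)C1(c1ccc(O)cc1)C1CCCC1` at 12 nM
compound 2 `Cc1ccc2c(c1C)NC(=O)C2(c1ccc(O)cc1)C1CCCCCC1` at 19 nM
compound 3 `Cc1ccc2c(c1Cl)NC(=O)C2(c1ccc(O)cc1)C1CCCCCC1` at 2.8 nM

Compound 2 cannot be separated from compound 1 within the scatter, while compound 3 lies clearly lower. Compound 4 `COc1ccc2c(c1C)NC(=O)C2(c1ccc(O)cc1)C1CCCCCC1` is compound 2 with methoxy in place of methyl on an aromatic carbon. Within the data shown here, the only measured step (a 6.8-fold lower number from compound 2 to compound 3 (0.83 log units; beyond the scatter)) put chloro in place of a different methyl group of compound 2, so it is a weak guide for methoxy, and no step beyond the scatter is expected in this assay here. Compound 4 is expected at 15 nM within a range from 5 nM to 45 nM once measured. The estimated shift is a 1.3-fold lower number from compound 2 to compound 4 (0.10 log units; within the scatter) and so stays small.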

Compound 4, half-maximal inhibitory concentration: 4.7 nM
Beside the measured number, compound 4's estimate is 3.2-fold (0.50 log units) above it; the measured number lies below the stated range.
By their numbers in this assay, from the lowest: compounds 3 and 4 (each within the scatter of the next); then compounds 1 and 2 (each within the scatter of the next).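

In this assay, methoxy in place of methyl at this position, para to a fused ring, gives a 4.0-fold lower number from compound 2 to compound 4 (0.61 log units; beyond the scatter). The earlier step, a 6.8-fold lower number from compound 2 to compound 3 (0.83 log units; beyond the scatter), changed the other methyl group, so this result shows that the number also responds to a change at this second place on the ring. Nothing shown explains why the number falls with methoxy here.

Going by these compounds, whether an amine, a hydroxyl or an ethoxy at this place would give a similar number remains open.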